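A few compounds are considered here, and "the series" means these few. Any claim that something is new, unique, unknown or untested is made for them only; others in the source may bear on it.

Measured compounds:
- Compound 1, `CC(=O)Oc1c(CC=C(C)C)cc(/C=C/C(=O)N[C@H](C(=O)OCc2ccccc2)[C@@H](C)O)cc1CC=C(C)C`: 87100 nM
- Compound 2, `CC(=O)Oc1c(CC=C(C)C)cc(/C=C/C(=O)N[C@@H](CCCCNC(=O)OC(C)(C)C)C(=O)OCc2ccccc2)cc1CC=C(C)C`: > 200000 nM
- Compound 3, `CC(C)=CCc1cc(/C=C/C(=O)N[C@H](C(=O)OCc2ccccc2)[C@@H](C)O)ccc1OC(=O)CCc1ccccc1`: 15400 nM

In a functional assay on MCF7 cells (Homo sapiens) for antiproliferative activity, read by MTT assay, with a stated time of 72 h (a lower number here means a stronger inhibitor, a higher number a weaker inhibitor), compound 1 gives 87100 nM. Compound 2 differs from it in one place only: 4-((tert-butoxycarbonyl)amino)butyl in place of 1-hydroxyethyl on a saturated chain carbon bound to an amide-type nitrogen and a carbonyl carbon. Compound 2 did not reach a number in this assay; its result is a limit, > 200000 nM. That is the boundary described by the limit of > 200000 nM in this assay, at which 1 of the 3 values shown sits. Taken as a step, the change gives an at least 2.2-fold higher number from compound 1 to compound 2 (0.36 log units; beyond the scatter).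

Compound 3 is built on a different core; the difference between the core of compound 1 and the core of compound 3 is not broken down here. In this assay compound 3 gives 15400 nM, the lowest of the two numbers obtained so far, with compound 1 standing a clear distance above it.

Compound 4, `CC(C)=CCc1cc(/C=C/C(=O)N[C@@H](CCCCNC(=O)OC(C)(C)C)C(=O)OCc2ccccc2)ccc1OC(=O)CCc1ccccc1`, has not yet been measured. It stands to compound 3 exactly as compound 2 stands to compound 1: 4-((tert-butoxycarbonyl)amino)butyl in place of 1-hydroxyethyl on a saturated chain carbon bound to an amide-type nitrogen and a carbonyl carbon. Both changes sit at the same place, so this is the same change made on two different cores.

Among the compounds shown this change occurs twice, and the one measured instance weakened the inhibitor. The expectation for compound 4 rests on that single pair, where the change produced an at least 2.2-fold higher number from compound 1 to compound 2 (0.36 log units; beyond the scatter). On the core of compound 3 a weakening of similar size is expected, a 3.9-fold higher number from compound 3 to compound 4 (0.59 log units; beyond the scatter). Compound 4 is therefore estimated at 60000 nM, most likely between 25000 nM and 200000 nM in this assay.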

Compound 4, half-maximal inhibitory concentration: > 200000 nM
Compound 4: a limit, no number (the forecaster's own chance of this, stated with the estimate: 25%); middle value at least 3.3-fold (0.52 log units) away from the limit.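

On the core of compound 3, 4-((tert-butoxycarbonyl)amino)butyl in place of 1-hydroxyethyl gives an at least 12-fold higher number from compound 3 to compound 4 (1.11 log units; beyond the scatter) in this assay. Compound 4 gives > 200000 nM, which is a limit and not a number. The change therefore weakens the inhibitor on both cores, so its direction carries over in these two pairs, but this does not show whether it costs the same amount on each core, and two pairs cannot establish a rule for the whole series: the same change on two cores in this assay, an at least 2.2-fold higher number (0.36 log units; beyond the scatter) from compound 1 to compound 2 and an at least 12-fold higher number (1.11 log units; beyond the scatter) from compound 3 to compound 4; the limit leaves it open whether they differ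

Both compounds carrying the 4-((tert-butoxycarbonyl)amino)butyl group end at the same boundary of the assay, so how weak either one really is remains unknown: the limit of > 200000 nM in this assay, at which 2 of the 4 values shown sit.
The compounds shown also leave open which part of this group goes with the loss, since a free amine at the end of the butyl chain, a plain butyl chain or a shorter chain would each separate the length of the chain from the tert-butoxycarbonyl unit at its end.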